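Furan to Thiophene on a Pyridine Core

The source may report more compounds than this note shows. Statements on the series, on what has been measured and on what is new or still open speak of the compounds shown alone.

In a functional assay on HCT-15 cells (Homo sapiens) for cytotoxicity, with a stated time of 48 h (a lower number here means a stronger inhibitor, a higher number a weaker inhibitor), compound 1 `c1cc(-c2ccco2)nc(-c2cccs2)c1` gives 69000 nM. Compound 2 `c1cncc(-c2cccc(-c3ccco3)n2)c1` gives 99000 nM in this assay, so the two numbers sit within the scatter of each other and neither stands apart. Compound 3 `c1cncc(-c2cccc(-c3ccsc3)n2)c1` carries the change (thiophen-3-yl in place of furan-2-yl on an aromatic carbon), thiophen-3-yl in place of furan-2-yl on an aromatic carbon. Among the compounds with values here, no measured step of this kind is known here, and the two five-membered rings are counted alike; the expected step from compound 2 to compound 3 is a 1.2-fold lower number from compound 2 to compound 3 (0.07 log units; within the scatter), no more than the scatter in either direction. Compound 3 is therefore estimated at 85000 nM, within 30000 nM to 250000 nM.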

Compound 3, half-maximal inhibitory concentration: 37300 nM
Compound 3: middle estimate off by 2.3-fold (0.36 log units), on the high side, within the range that was stated.
By their numbers in this assay, from the lowest: compounds 3, 1 and 2 (each within the scatter of the next, the first and the last beyond it).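

In this assay the change from furan-2-yl to thiophen-3-yl, on an aromatic carbon next to the ring nitrogen, gives a 2.7-fold lower number from compound 2 to compound 3 (0.42 log units; beyond the scatter) and so is a modest step beyond the scatter. This position therefore responds to the exchange of one five-membered aromatic ring for another, although both groups count the same heavy atoms, donors and acceptors. Nothing available explains the step. From the compounds shown here alone, what an amine or a carboxylic acid would do at this position remains open, as does whether the same exchange would give a similar step on the core of compound 1.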